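Adding a hydroxy group to the aniline ring of compound 3

This account rests on a few compounds, and the source may have more. Where it says the series, first, only, none or still open, it means among the compounds named here.

Three compounds share one core and differ only in the aromatic ring on a nitrogen. In a functional assay on K562 cells (Homo sapiens) for inhibition, read by fluorescence, with a stated time of 72 h (a higher number here means a weaker inhibitor of growth, a lower number a stronger inhibitor of growth), compound 1 (`CC(C)CCn1cnc2c(Nc3ccc(Cl)cc3)nc(N[C@H]3CC[C@H](N)CC3)nc21`), with a 4-chlorophenyl group, gives 1800 nM. Compound 2 (`COc1cc(Nc2nc(N[C@H]3CC[C@H](N)CC3)nc3c2ncn3CCC(C)C)cc(OC)c1`), with a 3,5-dimethoxyphenyl group, gives 2500 nM. Compound 3 (`CC(C)CCn1cnc2c(Nc3ccccc3)nc(N[C@H]3CC[C@H](N)CC3)nc21`), with a plain phenyl group, gives 3500 nM. That value sits within the scatter of both others, so these three cannot be ranked.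

Compound 4 (`CC(C)CCn1cnc2c(Nc3ccc(O)cc3)nc(N[C@H]3CC[C@H](N)CC3)nc21`) changes compound 3 at one place: hydroxy in place of hydrogen on an aromatic carbon, para to a large group (hydroxy in place of hydrogen on an aromatic carbon). Going by the values given here, no compound with a hydroxy group has been measured, so the evidence is indirect. The closest measured change concerns hydrogen and chloro on that ring, a 1.9-fold higher number from compound 1 to compound 3 (0.29 log units; within the scatter). Exchanging the whole ring gave a 1.4-fold higher number from compound 1 to compound 2 (0.14 log units; within the scatter) and a 1.4-fold higher number from compound 2 to compound 3 (0.15 log units; within the scatter). All three steps are small, so no step beyond the scatter is expected in this assay, though a surprise remains possible with a group not yet tried. The expected change is a 1.3-fold lower number from compound 3 to compound 4 (0.10 log units; within the scatter). The estimated value for compound 4 is 2800 nM, with an expected range from 1100 nM to 7000 nM.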

Compound 4, concentration for 50% growth inhibition: 4600 nM
For compound 4 the middle estimate is 1.6-fold (0.22 log units) below the measured one; the range from low to high includes it.
By their numbers in this assay, from the lowest: compounds 1, 2, 3 and 4 (each within the scatter of the next, the first and the last beyond it).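

In this assay, hydroxy in place of hydrogen on this aromatic carbon, para to a large group, gives a 1.3-fold higher number from compound 3 to compound 4 (0.12 log units; within the scatter) and so does not separate the two compounds, while the change of the whole ring to 4-hydroxyphenyl gives a 1.8-fold higher number from compound 2 to compound 4 (0.26 log units; within the scatter) and does not separate those two either. Going by these compounds alone, the new information comes from hydroxy in place of chloro on the same carbon, which gives a 2.6-fold higher number from compound 1 to compound 4 (0.41 log units; beyond the scatter) and is the first step in this small set to pass the scatter, although only modestly, with the hydrogen compound lying within the scatter of both. The substituent on this carbon can therefore shift the growth-inhibition value a little, but no measurement here explains the gap between chloro and hydroxy.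

Methoxy, an amine or a carboxylic acid on this carbon could show whether chloro and hydroxy mark the ends of a wider spread of values or sit inside one. As far as these compounds go, it also remains open whether the gap between chloro and hydroxy would persist if another part of the shared core were changed.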